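This account rests on a few compounds, and the source may have more. Where it says the series, first, only, none or still open, it means among the compounds named here.

Compound 1 `COc1cc2cc(Oc3ccc(NC(=O)Nc4cccc(C(F)(F)F)c4)cc3)c(C)nc2cc1OC`: > 50000 nM
Compound 2 `COc1cc2cc(Oc3ccc(NC(=O)Nc4ccc(Cl)c(C(F)(F)F)c4)cc3)c(C)nc2cc1OC`: 17400 nM

In a functional assay on OVCAR-5 cells (Homo sapiens) for inhibition, read by sulforhodamine B assay, with a stated time of 48 h (a higher number here means that more compound is tolerated, a lower number that less compound is tolerated), compound 1 reaches only a limit of the assay, > 50000 nM. In this assay, among the measured compounds shown here, compound 2 gives 17400 nM, the only plain number among the two values. For the measured compounds named here, the one measured step is an at least 2.8-fold lower number from compound 1 to compound 2 (0.45 log units; beyond the scatter), a chloro added where hydrogen stood. Compound 3 `COc1cc2cc(Oc3ccc(NC(=O)Nc4ccc(Cl)c(Cl)c4)cc3)c(C)nc2cc1OC` differs from compound 2 by chloro in place of trifluoromethyl on an aromatic carbon. Going by the values given here, no measured step swaps these two groups, so the expected step of a 1.1-fold higher number from compound 2 to compound 3 (0.06 log units; within the scatter) is set within the scatter. Compound 3 is therefore estimated at 20000 nM, between 8000 nM and 50000 nM.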

Compound 3, concentration lethal to 50% of the cells: > 100000 nM
Compound 3 ended at the assay's limit; the forecaster's own chance of this, stated with the estimate: 25%; middle value at least 5.0-fold (0.69 log units) away from the limit.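

In this assay, chloro in place of trifluoromethyl on this aromatic carbon, ortho to a chloro group, gives an at least 5.7-fold higher number from compound 2 to compound 3 (0.75 log units; beyond the scatter), so the two groups are not interchangeable here. The earlier step changed only the other place on this ring, so it could not show that trifluoromethyl matters at this position. Compound 3 gives only a limit, and the step to it from compound 1, itself a limit, cannot be read: the limit of > 100000 nM in this assay, at which 1 of the 3 values shown sits.

Still open, as far as these compounds go, is how a bromo or a nitrile would read at this position. From the compounds shown here alone, how far past its limit compound 3 really lies also remains unknown.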